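A few compounds are considered here, and "the series" means these few. Any claim that something is new, unique, unknown or untested is made for them only; others in the source may bear on it.

Measured so far in a toxicity assay on KB cells (Homo sapiens) for cytotoxicity, read by fluorescence, with a stated time of 3 days; a higher number here means that more compound is needed for the effect, a lower number that less compound is needed:
- Compound 1 `CCCCOC(=O)CNC(=O)[C@H](CSc1ccc([N+](=O)[O-])cc1[N+](=O)[O-])NC(=O)CC[C@H](NC(=O)CCC(C)C)C(=O)OCCCC`: 84 uM
- Compound 2 `CCCCOC(=O)CNC(=O)[C@H](CSc1ccc([N+](=O)[O-])cc1[N+](=O)[O-])NC(=O)CC[C@H](Nc1nc(N)nc(Cl)n1)C(=O)OCCCC`: > 300 uM

Compound 2 has no number on this scale. Its entry of > 300 uM is a limit of the assay.

Compound 3 `CCCCOC(=O)CNC(=O)[C@H](CSc1ccc([N+](=O)[O-])cc1[N+](=O)[O-])NC(=O)CC[C@H](NC(=O)C(C)C)C(=O)OCCCC` is the next to be read in this assay. Relative to compound 2 it carries isopropylcarbonyl in place of 4-amino-6-chloro-1,3,5-triazin-2-yl on an amine nitrogen.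

Among the measured compounds shown here, one measured step bears on this change: an at least 3.5-fold higher number from compound 1 to compound 2 (0.55 log units; beyond the scatter). That step put the same triazinyl group in place of isopentylcarbonyl on the amine nitrogen, so the present change runs the opposite way, from the triazinyl group back to a carbonyl group. For the measured compounds named here, the enterng group is not the one lost in that step, and a single step is thin support. A lower number than the limit of compound 2 is still the expected direction, by a modest margin beyond the scatter.

The expected step is an at least 2.5-fold lower number from compound 2 to compound 3 (0.39 log units; beyond the scatter).

For compound 3 the estimated value is 120 uM, with an expected range of 50 uM to 300 uM.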

Compound 3, concentration for half-maximal effect: > 300 uM
Compound 3: a limit, no number (the forecaster's own chance of this, stated with the estimate: 20%); middle value at least 2.5-fold (0.39 log units) from the limit.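

At the amine nitrogen in this assay, a carbonyl group alone does not preserve the lower number: isopropyl in place of isopentyl on the carbonyl carbon gives an at least 3.5-fold higher number from compound 1 to compound 3 (0.55 log units; beyond the scatter). Compound 3 gives > 300 uM, which is a limit of the assay and not a number. Among the compounds shown here, the step from the triazinyl compound to the isopropylcarbonyl compound therefore cannot be read, the two cannot be ordered, and compound 1 is the only one with a number on this scale: the limit of > 300 uM in this assay, at which 2 of the 3 values shown sit.

With a single numerical value, the compounds shown do not establish how the number in this assay follows the length of the chain on the carbonyl carbon, or whether the difference between isopropyl and isopentyl reflects chain length or branching. Open comparisons at this amine nitrogen include a longer chain, such as hexylcarbonyl, an unbranched butylcarbonyl group, and the free amine, each of which could show whether the number moves further from that of compound 1 or stays within reach of the limit.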